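Trifluoromethyl for fluoro in a meta-substituted benzyl ether

This account rests on a few compounds, and the source may have more. Where it says the series, first, only, none or still open, it means among the compounds named here.

Of the compounds shown here, three have been tested in an assay on isolated protein for inhibition of Amine oxidase [flavin-containing] B (Homo sapiens), read by Amplex Red, with a stated time of 15 min; a lower number here means a stronger inhibitor, a higher number a weaker inhibitor. Compound 1 `CC(=O)c1ccc(OCc2cccc([N+](=O)[O-])c2)cc1` gives 104 nM, compound 2 `CC(=O)c1ccc(OCc2ccccc2C(F)(F)F)cc1` gives 183 nM, and compound 3 `CC(=O)c1cccc(OCc2cccc(F)c2)c1` gives 193 nM. Compound 3 carries the highest of the three numbers, but its gap to compound 2 and to compound 1 lies within the scatter, so no order among them can be claimed. Compound 4 `CC(=O)c1cccc(OCc2cccc(C(F)(F)F)c2)c1` has not yet been measured in this assay . It differs from compound 3 in one place: trifluoromethyl in place of fluoro on an aromatic carbon. Among the compounds with values here, no measured pair shows this change, so the size of the step is open. Compound 4 is expected to give 120 nM (range 45 nM to 320 nM), which means an estimated step of a 1.6-fold lower number from compound 3 to compound 4 (0.21 log units; within the scatter), at most a modest move toward a lower number.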

Compound 4, half-maximal inhibitory concentration: 21.2 nM
Compound 4: the middle estimate sits 5.7-fold (0.75 log units) above what was measured; the measured number lies below the stated range.
By their numbers in this assay, from the lowest: compound 4; then compounds 1, 2 and 3 (each within the scatter of the next).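

In this assay, within the data shown here, trifluoromethyl in place of fluoro on this aromatic carbon gives a 9.1-fold lower number from compound 3 to compound 4 (0.96 log units; beyond the scatter), the first step to lie beyond the scatter. The number therefore responds to the group at this position, which the three earlier compounds could not show. Nothing measured here accounts for the step. From the compounds shown here alone, whether chloro, methoxy or nitrile on the same carbon would give a similar number remains open. So does whether this change would have a step of similar size on the core of compound 1.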